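This account rests on a few compounds, and the source may have more. Where it says the series, first, only, none or still open, it means among the compounds named here.

Compound 1 `COc1nc(C2CCOCC2)ccc1[C@@H](c1ccccc1)[C@@](O)(CCN(C)C)c1cccc2ccccc12` carries an oxan-4-yl group on the shared core; in a toxicity assay on HeLa cells (Homo sapiens) for cytotoxicity (on this read-out lower numbers stand for higher toxicity in this test and higher numbers for lower toxicity in this test), compound 1 gives 22.5 ug/mL. Compound 2 `COc1nc(-c2ccsc2)ccc1[C@@H](c1ccccc1)[C@@](O)(CCN(C)C)c1cccc2ccccc12` carries thiophen-3-yl there; in this assay compound 2 reaches only a limit of the assay, > 64 ug/mL. Compound 3 `COc1nc(C(C)(C)C)ccc1[C@@H](c1ccccc1)[C@@](O)(CCN(C)C)c1cccc2ccccc12` carries tert-butyl; in this assay compound 3 also sits at a limit, > 64 ug/mL. Compound 3 thus stands at the limit of > 64 ug/mL in this assay, at which 2 of the 3 values shown sit. Compound 4 `COc1nc(-c2ccccc2Cl)ccc1[C@@H](c1ccccc1)[C@@](O)(CCN(C)C)c1cccc2ccccc12` differs from compound 3 by 2-chlorophenyl in place of tert-butyl on an aromatic carbon. Within the data shown here, the steps that bear on it are an at least 2.8-fold higher number from compound 1 to compound 2 (0.45 log units; beyond the scatter) and an at least 2.8-fold higher number from compound 1 to compound 3 (0.45 log units; beyond the scatter), while a step that the two limits leave unreadable from compound 2 to compound 3. Compound 4 is expected to stay near the limit, with an at least 1.2-fold lower number from compound 3 to compound 4 (0.10 log units; that floor lies within the scatter). The estimate for compound 4 in this assay is 50 ug/mL, between 20 ug/mL and 64 ug/mL.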

Compound 4, half-maximal cytotoxic concentration: > 64 ug/mL
Compound 4: a limit, no number (the forecaster's own chance of this, stated with the estimate: 55%); middle value at least 1.2-fold (0.10 log units) away from the limit.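

With 2-chlorophenyl next to the ring nitrogen, compound 4 in this assay also gives only a limit of the assay, > 64 ug/mL. The change from oxan-4-yl reads as an at least 2.8-fold higher number from compound 1 to compound 4 (0.45 log units; beyond the scatter), while the steps among compound 2, compound 3 and compound 4 cannot be read. An aromatic ring bearing chlorine thus joins thiophen-3-yl and tert-butyl, with only compound 1 going against them: the limit of > 64 ug/mL in this assay, at which 3 of the 4 values shown sit.

From the compounds shown here alone, how far these three groups differ from one another in this test stays open. So does whether an amine or a carboxylic acid at this position would give a readable number.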